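Replacing the dienyl chain with cyclohexyl on the shared core

The source may hold more compounds than are shown below. What is called first, only, known or untested is meant among the compounds shown, and "the series" means these compounds.

Compound 1, `Cc1cc(O)c(CC(O)C(C)CC[C@H]2[C@@H](C)CCCC2(C)C)c(O)c1C=O`: 16000 nM
Compound 2, `C=C(CC/C=C(\C)CCC=C(C)C)C(O)Cc1c(O)cc(C)c(C=O)c1O`: > 80000 nM

Of the compounds shown here, two sharing one core have been tested in an ADME assay on EC17 cells (Homo sapiens) for cytotoxicity, read by trypan blue exclusion; a lower number here means a stronger inhibitor, a higher number a weaker inhibitor. Compound 1 gives 16000 nM. For compound 2 only a limit of the assay is known, > 80000 nM; it sits at the limit of > 80000 nM in this assay, at which 1 of the 2 values shown sits. Compound 3, `C=C(CCC1CCCCC1)C(O)Cc1c(O)cc(C)c(C=O)c1O`, has not yet been measured. It differs from compound 2 in one place: cyclohexyl in place of 2,6-dimethylhepta-1,5-dien-1-yl on a saturated chain carbon, two bonds along the chain from a double-bonded chain carbon. With compound 2 sitting at a limit, a step toward stronger inhibition is plausible but unproven, and another limit is a real possibility. Compound 3 is expected to give 50000 nM, within 15000 nM to 160000 nM, meaning an at least 1.6-fold lower number from compound 2 to compound 3 (0.20 log units; that floor lies within the scatter).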

Compound 3, half-maximal inhibitory concentration: 87000 nM
For compound 3 the middle estimate is 1.7-fold (0.24 log units) below the measured one; low and high end bracket the measured number.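

No step can be read from compound 2 to compound 3: compound 2 is known only as a limit of this assay, > 80000 nM. The compounds shown leave open whether cyclohexyl in place of 2,6-dimethylhepta-1,5-dien-1-yl changes the number at all, and in which direction.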